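Shrinking the Ring Once More: Cyclopentyl to Cyclobutyl

The source may report more compounds than this note shows. Statements on the series, on what has been measured and on what is new or still open speak of the compounds shown alone.

Measured so far:
- compound 1 `O=C(NC1CCCCC1)Oc1cccc(-c2ccccc2)c1` gives 0.1 h
- compound 2 `O=C(NCCCCc1ccccc1)Oc1cccc(-c2ccccc2)c1` gives 0.322 h
- compound 3 `O=C(NC1CCCC1)Oc1cccc(-c2ccccc2)c1` gives 0.0417 h

These half-lives come from an in vitro ADME assay on S9 fraction from liver (Rattus norvegicus, strain Wistar) for metabolic stability, read by HPLC, tested at 1 uM; on this read-out higher numbers stand for a longer-lived compound and lower numbers for a shorter-lived compound. Compound 3 gives the lowest number of the three, with compound 1 the nearest and compound 2 the highest. Compound 4 `O=C(NC1CCC1)Oc1cccc(-c2ccccc2)c1` differs from compound 3 by cyclobutyl in place of cyclopentyl on an amide-type nitrogen. For the measured compounds named here, the only measured step that bears on this change is a 2.4-fold lower number from compound 1 to compound 3 (0.38 log units; beyond the scatter), where a smaller ring on the same amide-type nitrogen gave a modestly lower number. Resting on that single step, a further small decrease, or no change beyond the scatter, is the likeliest outcome in this assay. The expected step is a 1.5-fold lower number from compound 3 to compound 4 (0.17 log units; within the scatter). Compound 4 is therefore estimated at 0.028 h, within a range of 0.012 h to 0.07 h.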

Compound 4, half-life in the liver assay: 0.0417 h
Compound 4: middle estimate off by 1.5-fold (0.17 log units), on the low side; the measured number falls inside the stated range.
By their numbers in the liver assay, from the lowest: compounds 3 and 4 (each within the scatter of the next); then compound 1; then compound 2.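

In the liver assay, the ring can shrink further here without a measurable cost: no change at the digits printed from compound 3 to compound 4 (within the scatter), while a 2.4-fold lower number from compound 1 to compound 4 (0.38 log units; beyond the scatter). Cyclobutyl and cyclopentyl therefore cannot be told apart by half-life on this amide-type nitrogen, though both differ from cyclohexyl. Yet in a physicochemical assay, read by HPLC, in phosphate buffer, at pH 7.0 (on this read-out higher numbers stand for a more stable compound and lower numbers for a less stable compound), compound 3 gives 34.4% and compound 4 gives 22.6%, so the same change that leaves the half-life flat lowers the percent remaining beyond the scatter.

From the compounds shown here alone, whether cyclopropyl or an open-chain isopropyl group would follow the same pattern stays open. So does how much of the loss in the liver assay would happen in buffer alone.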